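Aryl swap on the shared core: from bromophenyl to fluorophenyl

The source may hold more compounds than are shown below. What is called first, only, known or untested is meant among the compounds shown, and "the series" means these compounds.

Compound 1 `Brc1cn2ccnc2c(-c2ccc3ncn(C4CCCCC4)c3c2)n1`: 5.21%
Compound 2 `Brc1ccc(-c2cn3ccnc3c(-c3ccc4ncn(C5CCCCC5)c4c3)n2)cc1`: 20.9%

Of the compounds shown here, two have been measured in a functional assay on HT-29 cells (Homo sapiens) for inhibition, read by sulforhodamine B assay, with a stated time of 48 h, tested at 10 uM; on this read-out higher numbers stand for more inhibition at the one concentration tested (going by the name of the read-out) and lower numbers for less inhibition. Compound 1 gives 5.21% in this assay, and compound 2 gives 20.9%. Among the measured compounds shown here, compound 2 therefore stands highest of the two numbers, with compound 1 as its only neighbour, and the step of a number 15.7 percentage points higher from compound 1 to compound 2 (beyond the scatter) lies beyond the scatter.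

Compound 3 `Fc1ccccc1-c1cn2ccnc2c(-c2ccc3ncn(C4CCCCC4)c3c2)n1` has not yet been measured. It differs from compound 2 in one place: 2-fluorophenyl in place of 4-bromophenyl on an aromatic carbon.

For the measured compounds named here, the single measured step, a number 15.7 percentage points higher from compound 1 to compound 2 (beyond the scatter), bears on this change only loosely: it exchanged a bromo for a 4-bromophenyl, whereas the change to compound 3 exchanges one six-membered aromatic ring of carbon only for another of the same size. Going by the values given here, no measured step shows what such an aryl-for-aryl exchange does in this assay. The expected step is therefore a number 4.9 percentage points lower from compound 2 to compound 3 (within the scatter), which is taken to be within the scatter. Compound 3 is estimated at 16% in this assay, in a range from 0% to 36%.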

Compound 3, a percentage reported as inhibition, at one concentration (the size of the read-out at that concentration, not a potency): 7.26%
Estimate against measurement, compound 3: 8.7 percentage points above, within the range that was stated.
By their numbers in this assay, from the lowest: compounds 1 and 3 (each within the scatter of the next); then compound 2.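

In this assay the aryl groups at this position, on an aromatic carbon next to the ring nitrogen, are not interchangeable: replacing 4-bromophenyl with 2-fluorophenyl gives a number 13.6 percentage points lower from compound 2 to compound 3 (beyond the scatter) even though both groups have the same count of heavy atoms and one six-membered aromatic ring of carbon only. Placing an aryl ring on this carbon is therefore not enough on its own to lift the read-out, since the exchange of bromo for 2-fluorophenyl gives only a number 2.1 percentage points higher from compound 1 to compound 3 (within the scatter) and the rise seen with 4-bromophenyl does not carry over to this group. Nothing measured here accounts for the difference between the two aryl groups.

The halogen and its place on the aryl ring change together in this step, so the compounds shown leave open which of the two matters; 4-fluorophenyl and 2-bromophenyl would separate them. Also open, from the compounds shown here alone, is how a phenyl ring carrying an amine or a carboxylic acid would read at this carbon, and whether any of these differences would hold at other concentrations.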